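Adding isobutyl to a compound stuck at the assay limit

The compounds below may be only part of what the source reports. "The series", "measured", "known", "first", "only" and "open" are said of these compounds alone.

In a functional assay on MCF7 cells (Homo sapiens) for antiproliferative activity, read by MTT assay, with a stated time of 48 h (on this read-out lower numbers stand for stronger inhibition and higher numbers for weaker inhibition), compound 3 `CC(C)(C)Nc1nc2ccccc2nc1Oc1ccc(C(=O)NCC(=O)O)cc1` gives > 50000 nM, which is a limit of the assay and not a number. Compound 2 `COC(=O)CNC(=O)c1ccc(Oc2nc3ccccc3nc2NC(C)(C)C)cc1` gives > 50000 nM, also a limit. Compound 3 therefore stands at the limit of > 50000 nM in this assay, at which 2 of the 3 values shown sit. Within the data shown here, the only measured step between close neighbours is a step that the two limits leave unreadable from compound 2 to compound 3, so it offers no size to build on.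

Compound 4 `CC(C)C[C@H](NC(=O)c1ccc(Oc2nc3ccccc3nc2NC(C)(C)C)cc1)C(=O)O` changes compound 3 in one place: isobutyl in place of hydrogen on a saturated chain carbon bound to an amide-type nitrogen and a carbonyl carbon. In other words, carboxymethyl becomes 1-carboxy-3-methylbutyl. The only clue to what this may do comes from compound 1 `Cc1nc2ccccc2nc1Oc1ccc(C(=O)N[C@@H](CC(C)C)C(=O)O)cc1`, which carries the same 1-carboxy-3-methylbutyl group but differs from compound 4 elsewhere on the core. Compound 1 gives a true number, 14700 nM, so this side chain can occur in a compound with a measurable reading in this assay. That clue is indirect, and the core difference could matter as much as the side chain.

The expected change is an at least 2.2-fold lower number from compound 3 to compound 4 (0.35 log units; beyond the scatter), towards stronger inhibition, though its true size cannot be read from a limit. For compound 4 the estimate is 22000 nM, with an expected range from 8000 nM to 50000 nM.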

Compound 4, half-maximal inhibitory concentration: 40300 nM
Beside the measured number, compound 4's estimate is 1.8-fold (0.26 log units) below it; measured number inside the range.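

Isobutyl on the saturated chain carbon bound to an amide-type nitrogen and a carbonyl carbon gives the first true number for a compound with the (tert-butyl)amino group: in this assay the change shows an at least 1.2-fold lower number from compound 3 to compound 4 (0.09 log units; that floor lies within the scatter), and the wider side-chain swap shows an at least 1.2-fold lower number from compound 2 to compound 4 (0.09 log units; that floor lies within the scatter). Compound 3 gives a limit and not a number, so this step is only a floor, and the real size could be larger: the limit of > 50000 nM in this assay, at which 2 of the 4 values shown sit. With the 1-carboxy-3-methylbutyl group held constant, the comparison with compound 1 shows a 2.7-fold higher number from compound 1 to compound 4 (0.44 log units; beyond the scatter), so in this pair (tert-butyl)amino in place of methyl on an aromatic carbon goes with modestly weaker inhibition.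

Going by these compounds, the step between compound 2 and compound 3 cannot be read, so the effect of hydrogen in place of methyl on that oxygen stays open. Also open, on these data alone, is whether isobutyl is special on that chain carbon, or whether a methyl or benzyl group there, or an amine in place of the carboxylic acid, would read differently.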